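Cytotoxicity in the thiocarbamate series: the fluoro analogue

The compounds below may be only part of what the source reports. "The series", "measured", "known", "first", "only" and "open" are said of these compounds alone.

Compound 1 `S=C(Nc1ccccc1)OCCc1ccccn1` is the parent of the series. In an ADME assay on MT4 cells (Homo sapiens) for cytotoxicity, read by MTT assay (a lower number here means that less compound is tolerated, a higher number that more compound is tolerated), compound 1 gives > 100000 nM, which is a limit of the assay and not a number. Compound 2 `Cc1cccc(NC(=S)OCCc2ccccn2)c1` gives > 100000 nM, again a limit. Compound 3 `CC(=O)c1ccc(NC(=S)OCCc2ccccn2)cc1` gives >= 100000 nM, also a limit. The two measured steps are accordingly a step that the two limits leave unreadable from compound 1 to compound 2 and a step that the two limits leave unreadable from compound 1 to compound 3; both sit on the limit of > 100000 nM in this assay, at which 2 of the 3 values shown sit, and (the limit of >= 100000 nM in this assay, at which 1 of the 3 values shown sits), so where compound 1 stands can be said only as a limit, with no number beneath it.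

Compound 4 `Fc1ccc(NC(=S)OCCc2ccccn2)cc1` differs from compound 1 by fluoro in place of hydrogen on an aromatic carbon. Both measured steps, methyl and acetyl in place of hydrogen on an aromatic carbon, bear on this change, and neither had a readable size. The expectation is that compound 4 likewise reaches the limit, so a number no higher from compound 1 to compound 4 (the limit leaves the size open) is expected to be no step beyond the scatter. Compound 4 is estimated at 100000 nM, within 50000 nM to 200000 nM.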

Compound 4, half-maximal cytotoxic concentration: > 100000 nM
Compound 4 gave a limit, no number (the forecaster's own chance of this, stated with the estimate: 85%); the middle value sits exactly at the limit.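

In this assay compound 4 gives > 100000 nM, a limit and not a number, so its steps from compound 1 and from compound 3 cannot be read. The compounds shown leave open whether fluoro, methyl or acetyl in place of hydrogen on an aromatic carbon changes the tolerated concentration at all.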